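This account rests on a few compounds, and the source may have more. Where it says the series, first, only, none or still open, it means among the compounds named here.

Three compounds that share one core and differ only in the group on a saturated chain carbon bound to an aromatic carbon have been measured in a functional assay on P388 cells (Mus musculus) for cytotoxicity; a lower number here means a stronger inhibitor, a higher number a weaker inhibitor. Compound 1 `Cc1cc(-c2c(F)cc3c(=O)c(Cc4cccc(O)c4)cn(C4CC4)c3c2F)cc(C)n1` gives 2200 nM, compound 2 `Cc1cc(-c2c(F)cc3c(=O)c(Cc4ccc[nH]4)cn(C4CC4)c3c2F)cc(C)n1` gives 930 nM, and compound 3 `Cc1cc(-c2c(F)cc3c(=O)c(Cc4ccc(O)cc4O)cn(C4CC4)c3c2F)cc(C)n1` gives 210 nM, the lowest number of the three. The next structure, compound 4 `Cc1cc(-c2c(F)cc3c(=O)c(Cc4ccccc4N)cn(C4CC4)c3c2F)cc(C)n1`, puts 2-aminophenyl in place of the 2,4-dihydroxyphenyl of compound 3 at that same place: 2-aminophenyl in place of 2,4-dihydroxyphenyl on a saturated chain carbon bound to an aromatic carbon. For the measured compounds named here, two measured steps bear on this change, since both end on the 2,4-dihydroxyphenyl group: a 10-fold lower number from compound 1 to compound 3 (1.02 log units; beyond the scatter) and a 4.4-fold lower number from compound 2 to compound 3 (0.65 log units; beyond the scatter). Neither the large step nor the modest one involves a 2-aminophenyl group, so they give only a rough guide. Going by the values given here, because compound 3 gives 210 nM, the lowest number so far, a modest step to a higher number is expected in this assay, rather than a further drop. The expected change is a 3.3-fold higher number from compound 3 to compound 4 (0.52 log units; beyond the scatter). Compound 4 is estimated at 700 nM, with an expected range of 200 nM to 2400 nM.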

Compound 4, half-maximal inhibitory concentration: 2100 nM
Estimate against measurement, compound 4: 3.0-fold (0.48 log units) below; measured number inside the range.
By their numbers in this assay, from the lowest: compound 3; then compound 2; then compounds 4 and 1 (each within the scatter of the next).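

Replacing 2,4-dihydroxyphenyl with 2-aminophenyl gives a 10-fold higher number from compound 3 to compound 4 (1.00 log units; beyond the scatter), so the low number of compound 3 does not carry over to this other substituted phenyl group on the saturated chain carbon. The 2-aminophenyl group also compares unfavourably with 1H-pyrrol-2-yl, with a 2.3-fold higher number from compound 2 to compound 4 (0.35 log units; beyond the scatter). Against 3-hydroxyphenyl the change gives a 1.0-fold lower number from compound 1 to compound 4 (0.02 log units; within the scatter), so these two phenyl groups cannot be told apart here, and both give higher numbers than 2,4-dihydroxyphenyl.

No measured property is available to explain these steps. As far as these compounds go, it remains open how 2-hydroxyphenyl or 4-hydroxyphenyl would stand in this assay, and so whether either hydroxyl group of 2,4-dihydroxyphenyl alone could account for the low number of compound 3.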